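Mixed substituent analogue of a symmetric series

The compounds below may be only part of what the source reports. "The series", "measured", "known", "first", "only" and "open" are said of these compounds alone.

Three symmetric compounds have been measured in a functional assay on L1210 cells (Mus musculus) for inhibition; on this read-out higher numbers stand for weaker inhibition and lower numbers for stronger inhibition. Compound 1 `C(C#Cc1ncnc2c1ncn2C1CCCCO1)#Cc1ncnc2c1ncn2C1CCCCO1` gives 700 nM. Compound 2 `C(#Cc1ncnc2c1ncn2Cc1ccccc1)c1ncnc2c1ncn2Cc1ccccc1` gives 1800 nM, the highest of the three numbers. Compound 3 `CCCCCn1cnc2c(C#Cc3ncnc4c3ncn4CCCCC)ncnc21` gives 1500 nM; the gap between compound 3 and compound 2 lies within the usual scatter, so the two cannot be told apart, whereas the gap from compound 2 to compound 1 lies beyond it, compound 1 having the lower number. No pair of these compounds differs in one place only, so no single step is known from measurement.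

Compound 4 `C(#Cc1ncnc2c1ncn2C1CCCCO1)c1ncnc2c1ncn2Cc1ccccc1` is the unsymmetric counterpart of compound 2: it carries oxan-2-yl in place of benzyl on an aromatic nitrogen. For the measured compounds named here, because compound 1 gives 700 nM against compound 2 at 1800 nM, replacing only one of the two groups is expected to move the number downward, though by less than the whole gap between these two compounds. The expected step is small and may fall within the scatter: a 1.6-fold lower number from compound 2 to compound 4 (0.21 log units; within the scatter). Compound 4 is therefore estimated at 1100 nM, within a range from 500 nM to 2500 nM.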

Compound 4, half-maximal inhibitory concentration: 900 nM
Compound 4: middle estimate off by 1.2-fold (0.09 log units), on the high side; the measured number falls inside the stated range.
By their numbers in this assay, from the lowest: compounds 1, 4, 3 and 2 (each within the scatter of the next, the first and the last beyond it).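

In this assay the series now has its first single-place reading: oxan-2-yl in place of benzyl on an aromatic nitrogen gives a 2.0-fold lower number from compound 2 to compound 4 (0.30 log units; within the scatter), so this one exchange does not separate the two compounds. The symmetric compounds could not show this, since each differs from the others at both ends at once. Compound 4 also lies within the scatter of compound 1, a pair differing by the same kind of exchange at the other end, so neither single exchange is resolved on its own. Nothing available accounts for the size of this step.

Open, as far as these compounds go, is whether the step holds with pentyl as the partner group on the other end. Also open, from the compounds shown here alone, is how a carboxylic acid or an amine-bearing chain on this aromatic nitrogen would read in this assay.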